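The source may hold more compounds than are shown below. What is called first, only, known or untested is meant among the compounds shown, and "the series" means these compounds.

Working notes on the sulfonamide series.

Of the compounds shown here, two have numbers so far. Compound 1 `O=S(=O)(NCCCNCc1ccc(Cl)c(C(F)(F)F)c1)c1cc(C(F)(F)F)cc(C(F)(F)F)c1` gives 7900 nM in a toxicity assay on MCF-10A cells (Homo sapiens) for inhibition, read by MTT assay, with a stated time of 72 h; a higher number here means a weaker inhibitor of growth, a lower number a stronger inhibitor of growth. Compound 2 `CC(C)(C)c1ccc(CNCCNS(=O)(=O)c2cc(C(F)(F)F)cc(C(F)(F)F)c2)cc1` gives 14000 nM in this assay. Compound 1 carries the lowest of the two numbers, but compound 2 sits within the usual scatter of it, so the two cannot be placed in any order on what has been measured. Going by the values given here, no pair of measured compounds differs in a single place, so no measured step is available to calibrate the change that follows.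

Compound 3 `COc1ccccc1CNCCCNS(=O)(=O)c1cc(C(F)(F)F)cc(C(F)(F)F)c1` has not yet been measured in this assay. Relative to compound 1 the change is 2-methoxyphenyl in place of 4-chloro-3-(trifluoromethyl)phenyl on a saturated chain carbon bound to an amine nitrogen.

Among the compounds with values here, with no measured step of this kind to lean on, the expectation for compound 3 rests only on the two numbers above and on the change itself. The expected step in this assay is a 2.5-fold higher number from compound 1 to compound 3 (0.40 log units; beyond the scatter), a shift toward a higher number of modest size, most likely a little beyond the scatter but not far from it. For compound 3 the estimated value is 20000 nM, with a range from 7000 nM to 60000 nM.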

Compound 3, concentration for 50% growth inhibition: 5500 nM
Compound 3: middle estimate off by 3.6-fold (0.56 log units), on the high side, outside the stated range (below it).
By their numbers in this assay, from the lowest: compounds 3, 1 and 2 (each within the scatter of the next, the first and the last beyond it).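

Going by these compounds alone, this is the first measured step at this position: in this assay, exchanging 4-chloro-3-(trifluoromethyl)phenyl for 2-methoxyphenyl on a saturated chain carbon bound to an amine nitrogen gives a 1.4-fold lower number from compound 1 to compound 3 (0.16 log units; within the scatter), so the two compounds cannot be told apart here. The position therefore accepts a change from 11 heavy atoms with chlorine and fluorine to 8 heavy atoms with oxygen, including a group with a hydrogen-bond acceptor, without a readable shift in the number, although this rests on one pair on one chain and in one cell line. No measurement of any property of these groups bears on this result, and the step is left without an explanation.

Going by these compounds, whether the position stays this flat for a ring that is not carbon only, such as pyridyl, for a saturated group such as cyclohexyl, or for a ring carrying a carboxylic acid or an amine, remains open. Also open, on these data alone, is whether the same exchange gives a comparable step on a shorter or longer chain, since compound 1 and compound 3 share a single chain.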